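Removing One Methoxy Group: From Compound 2 to Compound 3

The source may hold more compounds than are shown below. What is called first, only, known or untested is meant among the compounds shown, and "the series" means these compounds.

Measured compounds:
compound 1, `COc1ccc(-c2cc(/C=C/C(=O)c3ccc(N)cc3)[nH]n2)cc1`: 92%
compound 2, `COc1cc(-c2cc(/C=C/C(=O)c3ccc(N)cc3)[nH]n2)cc(OC)c1OC`: 96%

In a functional assay on SNB-19 cells (Homo sapiens) for cytotoxicity, read by sulforhodamine B assay, with a stated time of 48 h, tested at 0.01 uM (on this read-out higher numbers stand for a weaker effect at the one concentration tested and lower numbers for a stronger effect), compound 1 gives 92%, and compound 2 gives 96%. Compound 2 stands at the higher of the two numbers, yet the gap to compound 1 is within the usual scatter, so the two cannot be told apart; both sit close to the top of the scale, meaning little effect at the single concentration tested.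

Compound 3, `COc1ccc(-c2cc(/C=C/C(=O)c3ccc(N)cc3)[nH]n2)cc1OC`, is not yet measured. It differs from compound 2 in one place: hydrogen in place of methoxy on an aromatic carbon. Among the measured compounds shown here, no step between measured compounds is available to guide the size of this change. Since both measured compounds already show almost no effect, the step of a number 2 percentage points lower from compound 2 to compound 3 (within the scatter) is expected to stay within the scatter. Compound 3 is therefore estimated at 94%, with a range from 82% to 104%.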

Compound 3, a percentage reported as activity, at one concentration (the size of the read-out at that concentration, not a potency): 96%
Beside the measured number, compound 3's estimate is 2 percentage points below it; the range from low to high includes it.
By their numbers in this assay, from the lowest: compounds 1, 2 and 3 (each within the scatter of the next).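

In this assay, among the compounds shown here, the step of no change at the digits printed from compound 2 to compound 3 (within the scatter) and the step of a number 4 percentage points higher from compound 1 to compound 3 (within the scatter) are the first comparisons between compounds that differ in one place, each an exchange of methoxy and hydrogen on an aromatic carbon. Neither exchange moves the read-out beyond the usual scatter, so at this single low concentration, this methoxy group, ortho to another methoxy group and meta to a large group, makes no difference that can be detected, although a flat result among compounds with so little effect says little about what the position could do. Nothing available explains this flat result.

Going by these compounds, what an amine, a hydroxyl group or a longer chain such as ethoxy would do on this carbon stays open. So does whether the methoxy exchange would still leave the read-out unchanged at a higher concentration, where the compounds might show a clearer effect.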